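Swapping a furan for a methyl on the shared core

The compounds below may be only part of what the source reports. "The series", "measured", "known", "first", "only" and "open" are said of these compounds alone.

Compound 1 `COc1cc(NC(=O)NNc2cc(-c3ccccc3)c3cnn(C)c3n2)cc(Cl)n1`: 31300 nM
Compound 2 `Cn1ncc2c(-c3ccc(F)cc3)cc(NNC(=O)Nc3cc(Cl)cc(Cl)c3)nc21`: 39100 nM
Compound 3 `Cc1nn(C)c2nc(NNC(=O)Nc3cc(Cl)nc(Cl)c3)cc(-c3ccco3)c12`: 69200 nM

In a functional assay on HCT-116 cells (Homo sapiens) for cytotoxicity, read by MTT assay, with a stated time of 48 h, in the presence of a further agent that is not named here (a higher number here means that more compound is needed for the effect, a lower number that less compound is needed), compound 3 gives 69200 nM. That lies within the usual scatter of compound 2 at 39100 nM, while compound 1 at 31300 nM needs less compound, a gap just beyond the scatter.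

Compound 4 `Cc1cc(NNC(=O)Nc2cc(Cl)nc(Cl)c2)nc2c1c(C)nn2C` is built like compound 3, but with methyl in place of furan-2-yl on an aromatic carbon. Going by the values given here, no two measured compounds differ in only one place, so the data do not show directly what such a swap does. Each measured compound carries a ring at that carbon, and compound 4 has none, which makes this a real step into the unknown. Still, the measured values sit close together, from compound 1 at 31300 nM to compound 3 at 69200 nM, so a large jump seems unlikely. The estimated change in this assay is a 1.2-fold higher number from compound 3 to compound 4 (0.06 log units; within the scatter), a small rise expected to stay within the scatter. For compound 4 the estimated value is 80000 nM, with an expected range of 30000 nM to 200000 nM.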

Compound 4, half-maximal effective concentration: > 100000 nM
Compound 4: only a limit was reported; the forecaster's own chance of this, stated with the estimate: 15%; middle value at least 1.2-fold (0.09 log units) away from the limit.
By their numbers in this assay, from the lowest: compounds 1, 2 and 3 (each within the scatter of the next, the first and the last beyond it). At a limit, above all of these: compound 4.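

In this assay compound 4 gives > 100000 nM, which is a limit of the assay and not a number. Methyl in place of furan-2-yl on this aromatic carbon, opposite the ring nitrogen, is the first change in this set made in only one place, and it reads as an at least 1.4-fold higher number from compound 3 to compound 4 (0.15 log units; that floor lies within the scatter), so only a floor for the change is known and its true size could be small or large. What is new is that a compound with no ring at this carbon does not come out with a lower number than compound 3, and it alone reaches the limit: the limit of > 100000 nM in this assay, at which 1 of the 4 values shown sits.

One step ending at a limit cannot say whether a ring at this carbon is what counts, or how far compound 4 really lies from compound 3. Going by these compounds, how an amine, a carboxylic acid or a longer chain at this carbon would read in this assay also stays open.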